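Swapping the aryl substituent on a kinase-binding core

A few compounds are considered here, and "the series" means these few. Any claim that something is new, unique, unknown or untested is made for them only; others in the source may bear on it.

Of the compounds shown here, three sharing one core have been tested in an assay for binding affinity to dual specificity mitogen-activated protein kinase kinase 4 (Homo sapiens), read by KINOMEscan, tested at 10 nM; on this read-out higher numbers stand for a weaker effect at the one concentration tested and lower numbers for a stronger effect. Compound 1 `CCCS(=O)(=O)Nc1ccc(F)c(C(=O)c2n[nH]c3ncc(-c4ccc(S(=O)(=O)NCC)cc4)cc23)c1F` gives 41%. Compound 2 `CCCS(=O)(=O)Nc1ccc(F)c(C(=O)c2n[nH]c3ncc(-c4ccc(NS(C)(=O)=O)cc4)cc23)c1F` gives 16%, and compound 3 `CCCS(=O)(=O)Nc1ccc(F)c(C(=O)c2n[nH]c3ncc(-c4ccc(C(N)=O)cc4)cc23)c1F` gives 4%, the lowest of the three numbers and thus the strongest effect seen here. The steps leading to it were a number 37 percentage points lower from compound 1 to compound 3 (beyond the scatter) and a number 12 percentage points lower from compound 2 to compound 3 (beyond the scatter). Compound 4 `CCCS(=O)(=O)Nc1ccc(F)c(C(=O)c2n[nH]c3ncc(-c4ccc(S(N)(=O)=O)cc4Cl)cc23)c1F` is not yet measured; it differs from compound 3 by 2-chloro-4-sulfamoylphenyl in place of 4-carbamoylphenyl on an aromatic carbon. The step of a number 37 percentage points lower from compound 1 to compound 3 (beyond the scatter) bears most on this change, since a sulfamoyl group again replaces the carbamoyl, with an added chlorine of unknown effect. The number for compound 4 is therefore expected to rise by a number 18 percentage points higher from compound 3 to compound 4 (beyond the scatter), giving an estimate of 22%, with a range from 5% to 50%.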

Compound 4, a percentage reported as activity, at one concentration (the size of the read-out at that concentration, not a potency): 23%
Compound 4: middle estimate off by 1 percentage points, on the low side, within the range that was stated.
By their numbers in this assay, from the lowest: compound 3; then compounds 2 and 4 (each within the scatter of the next); then compound 1.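

In this assay, replacing 4-carbamoylphenyl with 2-chloro-4-sulfamoylphenyl gives up part of the strong effect (a number 19 percentage points higher from compound 3 to compound 4 (beyond the scatter)). The new group still outperforms 4-(ethylsulfamoyl)phenyl (a number 18 percentage points lower from compound 1 to compound 4 (beyond the scatter)), but it cannot be told apart from 4-(methanesulfonamido)phenyl (a number 7 percentage points higher from compound 2 to compound 4 (within the scatter)). Nothing measured here explains these differences. From the compounds shown here alone, the chlorine and the sulfamoyl enter together, and their separate contributions remain unknown. Going by these compounds, whether a carboxylic acid or an amine on this phenyl ring would match the carbamoyl group of compound 3 also remains open.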